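Capping the hydroxymethyl of compound 3 with trifluoroethyl

A few compounds are considered here, and "the series" means these few. Any claim that something is new, unique, unknown or untested is made for them only; others in the source may bear on it.

Compound 3 `CCc1cccc2c(OC)c(-c3occ(C)c3CO)ccc12` stands lowest of the three numbers in a functional assay on SK-BR-3 cells (Homo sapiens) for cytotoxicity, read by MTT assay, with a stated time of 72 h (on this read-out lower numbers stand for an effect already at smaller amounts and higher numbers for an effect only at larger amounts of compound), where compound 3 gives 0.73 ug/mL. Compound 1 `CCOC(=O)c1c(C)coc1-c1ccc2c(CC)cccc2c1OC` gives 2.5 ug/mL and compound 2 `CCc1cccc2c(OC)c(-c3occ(C)c3C(=S)OC)ccc12` gives 6.3 ug/mL; the steps of a 3.4-fold lower number from compound 1 to compound 3 (0.53 log units; beyond the scatter) and an 8.6-fold lower number from compound 2 to compound 3 (0.94 log units; beyond the scatter) both lead toward the hydroxymethyl compound, and a 2.5-fold higher number from compound 1 to compound 2 (0.40 log units; beyond the scatter) separates the two esters. Compound 4 `CCc1cccc2c(OC)c(-c3occ(C)c3COCC(F)(F)F)ccc12` differs from compound 3 by 2,2,2-trifluoroethyl in place of hydrogen on an oxygen on a saturated carbon. Within the data shown here, no measured step alters this oxygen itself, so the bearing is indirect: every departure from the free hydroxymethyl among the measured compounds gave a higher number, as seen in a 3.4-fold lower number from compound 1 to compound 3 (0.53 log units; beyond the scatter) read backwards. A modest rise in this assay is therefore expected, as a 2.7-fold higher number from compound 3 to compound 4 (0.44 log units; beyond the scatter). Compound 4 is estimated at 2 ug/mL, with a range from 0.7 ug/mL to 6 ug/mL.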

Compound 4, concentration for half-maximal effect: 5.3 ug/mL
Compound 4: the middle estimate sits 2.7-fold (0.42 log units) below what was measured, within the range that was stated.
By their numbers in this assay, from the lowest: compound 3; then compound 1; then compounds 4 and 2 (each within the scatter of the next).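

Placing 2,2,2-trifluoroethyl on this oxygen gives the first direct reading at the hydroxymethyl in this assay, with a 7.3-fold higher number from compound 3 to compound 4 (0.86 log units; beyond the scatter), so a free hydrogen on this oxygen goes with the lowest number shown. The capped compound does not sit with the ester of compound 1, as a 2.1-fold higher number from compound 1 to compound 4 (0.33 log units; beyond the scatter), while a 1.2-fold lower number from compound 2 to compound 4 (0.08 log units; within the scatter) leaves it level with compound 2. Nothing measured here explains the rise at this oxygen.

Going by these compounds, whether a plain ethyl or methyl cap gives the same rise remains open, leaving the share of the three fluorine atoms unknown. On these data alone, an amine in place of the hydroxy is also open.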